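Fluoro removal from compound 3: expected step

A few compounds are considered here, and "the series" means these few. Any claim that something is new, unique, unknown or untested is made for them only; others in the source may bear on it.

In a functional assay on A549 cells (Homo sapiens) for antiproliferative activity, read by MTT assay, with a stated time of 48 h (on this read-out lower numbers stand for stronger inhibition and higher numbers for weaker inhibition), compound 1 (`O=[N+]([O-])c1ccc(-c2nn(-c3ccccc3)cc2C(Nc2nc3ccccc3s2)c2c(O)ccc3ccccc23)cc1`) gives 41300 nM, compound 2 (`Oc1ccc2ccccc2c1C(Nc1nc2ccccc2s1)c1cn(-c2ccccc2)nc1-c1cccc(Cl)c1`) gives 20400 nM and compound 3 (`COc1ccc2nc(NC(c3cn(-c4ccccc4)nc3-c3ccc(F)cc3)c3c(O)ccc4ccccc34)sc2c1`) gives 33600 nM, which lies within the scatter of both others. Compound 4 (`COc1ccc2nc(NC(c3cn(-c4ccccc4)nc3-c3ccccc3)c3c(O)ccc4ccccc34)sc2c1`) has hydrogen in place of fluoro on an aromatic carbon, 4-fluorophenyl to phenyl: hydrogen in place of fluoro on an aromatic carbon. Among the compounds with values here, the only measured step, a 2.0-fold lower number from compound 1 to compound 2 (0.31 log units; beyond the scatter), is modest and exchanges other substituents on the same aryl group, so it bears only indirectly. No shift beyond the scatter is therefore expected, and the estimated change is a 1.1-fold lower number from compound 3 to compound 4 (0.05 log units; within the scatter). Compound 4 is estimated at 30000 nM, with an expected range of 15000 nM to 60000 nM.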

Compound 4, half-maximal inhibitory concentration: 44600 nM
For compound 4 the middle estimate is 1.5-fold (0.17 log units) below the measured one, and the stated range covers the measured number.
By their numbers in this assay, from the lowest: compounds 2, 3, 1 and 4 (each within the scatter of the next, the first and the last beyond it).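

In this assay, the change from 4-fluorophenyl to phenyl gives a 1.3-fold higher number from compound 3 to compound 4 (0.12 log units; within the scatter), so the fluoro can be lost from this aromatic carbon without a shift beyond the scatter. Unlike the earlier step on this aryl group, this one removes a single atom and leaves an unsubstituted phenyl as the reference for the position. Nothing available accounts for the size of this step.

Going by these compounds, whether an amine or a carboxylic acid on this carbon would move the number beyond the scatter remains open. So does whether losing fluoro reads the same on a core without methoxy.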